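Working notes: from compound 2 to compound 3

The source may hold more compounds than are shown below. What is called first, only, known or untested is meant among the compounds shown, and "the series" means these compounds.

Compound 1 `COc1ccc(C2=C(c3cc(OC)c(OC)c(OC)c3)CC3CCCN3C2=O)cc1O`: > 100000 nM (a limit)
Compound 2 `COc1ccc(C2=C(c3ccc(SC)cc3)CC3CCCN3C2=O)cc1Br`: 6000 nM

Among the measured compounds shown here, in a functional assay on MCF-A cells (Homo sapiens) for cytotoxicity (a higher number here means a weaker inhibitor of growth, a lower number a stronger inhibitor of growth), compound 2 gives 6000 nM, the only actual number so far. Compound 1 stands at a limit of the assay, > 100000 nM. Compound 3 `CSc1ccc(C2=C(c3ccc(C)c(C)c3)C(=O)N3CCCC3C2)cc1` carries 3,4-dimethylphenyl in place of 3-bromo-4-methoxyphenyl on a double-bonded ring carbon. For the measured compounds named here, no measured step covers this change, so only a modest shift toward weaker growth inhibition in this assay is expected, with wide uncertainty. The estimated step is a 2.5-fold higher number from compound 2 to compound 3 (0.40 log units; beyond the scatter). Compound 3 is expected at 15000 nM, with an estimated range from 4000 nM to 60000 nM.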

Compound 3, concentration for 50% growth inhibition: 800 nM
Compound 3: the middle estimate sits 19-fold (1.27 log units) above what was measured, and the stated range ends above it.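

Among the compounds shown here, on the double-bonded ring carbon, 3,4-dimethylphenyl in place of 3-bromo-4-methoxyphenyl gives a 7.5-fold lower number from compound 2 to compound 3 (0.88 log units; beyond the scatter) in this assay, the first one-place comparison. With the 4-(methylsulfanyl)phenyl group held constant, growth inhibition at this position therefore survives the loss of both bromine and oxygen, and it strengthens. Nothing measured here accounts for the gain. Open, on these data alone, is whether the gain follows the two methyl groups or the absence of the bromo and methoxy groups, and whether an amine or a carboxylic acid on this phenyl ring would keep it.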